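Removing the carboxyphenyl arm: an expected loss of potency

The source may hold more compounds than are shown below. What is called first, only, known or untested is meant among the compounds shown, and "the series" means these compounds.

Compound 1 `O=C1C=CC2(C=C1)OC(=O)C(c1cc3ccccc3s1)=C2c1ccccc1`: 32900 nM
Compound 2 `O=C1C=CC2(C=C1)OC(=O)C(c1ccc(C(=O)O)cc1)=C2c1ccccc1`: 15200 nM

Of the compounds shown here, two sharing one core have been measured in a functional assay on MDA-MB-231 cells (Homo sapiens) for antiproliferative activity, read by MTT assay, with a stated time of 48 h; a higher number here means a weaker inhibitor, a lower number a stronger inhibitor. Compound 1 gives 32900 nM, and compound 2 gives 15200 nM. Compound 2 thus carries the lowest of the two numbers, with compound 1 the nearest, the step being a 2.2-fold lower number from compound 1 to compound 2 (0.34 log units; beyond the scatter), a modest change arising from 4-carboxyphenyl in place of 1-benzothiophen-2-yl on a double-bonded ring carbon.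

Compound 3 `O=C1C=CC2(C=C1)OC(=O)C=C2c1ccccc1` is not yet measured. It differs from compound 2 by hydrogen in place of 4-carboxyphenyl on a double-bonded ring carbon, next to the ring atom that bears a phenyl group. For the measured compounds named here, no measured step shows what happens when this arm is removed altogether; the single step from compound 1 to compound 2 only swaps one aromatic group for another and is of modest size. Going by the values given here, with no direct precedent, a weakening beyond the scatter is expected, since the group that distinguished compound 2 disappears. Compound 3 is therefore estimated at 35000 nM, within 12000 nM to 110000 nM, an expected step of a 2.3-fold higher number from compound 2 to compound 3 (0.36 log units; beyond the scatter).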

Compound 3, half-maximal inhibitory concentration: 15900 nM
Compound 3: middle estimate off by 2.2-fold (0.34 log units), on the high side; measured number inside the range.
By their numbers in this assay, from the lowest: compounds 2 and 3 (each within the scatter of the next); then compound 1.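

In this assay, the 4-carboxyphenyl arm on this double-bonded ring carbon turns out not to be needed for the activity seen: with hydrogen in its place, the result is a 1.0-fold higher number from compound 2 to compound 3 (0.02 log units; within the scatter) and the two compounds cannot be told apart. The group that sets itself apart at this position is instead 1-benzothiophen-2-yl, as replacing it with hydrogen gives a 2.1-fold lower number from compound 1 to compound 3 (0.32 log units; beyond the scatter) in a modest step, so an aromatic group on this carbon does not by itself bring a lower number. Nothing beyond these cell numbers bears on why the arm can be removed with so little consequence.

As far as these compounds go, it remains open whether any group on this carbon can bring the number clearly below those of compound 2 and compound 3, and an amine, a hydroxymethyl group or a longer alkyl chain would each put that to the test. It is also open how much the activity depends on the phenyl group on the neighbouring ring atom, or on the shared core itself, as every compound shown keeps both.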